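From 4-fluorobenzyl to 2-chlorobenzyl on the shared core

The compounds below may be only part of what the source reports. "The series", "measured", "known", "first", "only" and "open" are said of these compounds alone.

In a functional assay on HepG2 cells (Homo sapiens) for antiproliferative activity, read by MTT assay, with a stated time of 48 h (a higher number here means a weaker inhibitor, a lower number a stronger inhibitor), compound 1 `CCCCc1ccc2c(c1)C(=O)C(=O)N2` returns > 10000 nM as a limit, not a number. Compound 2 `C=CCN1C(=O)C(=O)c2cc(-c3ccc(OC)cc3)ccc21` gives 7090 nM and compound 3 `COc1ccc(-c2ccc3c(c2)C(=O)C(=O)N3Cc2ccc(F)cc2)cc1` gives 1120 nM as the lower of these two numbers. Going by the values given here, the one measured step at this place puts 4-fluorophenyl in place of vinyl and amounts to a 6.3-fold lower number from compound 2 to compound 3 (0.80 log units; beyond the scatter) in a single move. Among the compounds with values here, no measured step exchanges one substituted phenyl for another. Compound 4 `COc1ccc(-c2ccc3c(c2)C(=O)C(=O)N3Cc2ccccc2Cl)cc1` differs from compound 3 by 2-chlorophenyl in place of 4-fluorophenyl on a saturated chain carbon bound to an amide-type nitrogen in a ring with 2-chlorophenyl in place of 4-fluorophenyl, on a saturated chain carbon bound to an amide-type nitrogen in a ring. Compound 4 keeps an aromatic ring on that carbon, so a repeat of the earlier gain is not expected. The estimated step is a 1.2-fold higher number from compound 3 to compound 4 (0.06 log units; within the scatter) in this assay and none beyond the scatter is expected. Compound 4 is estimated at 1300 nM with an expected range from 450 nM to 4000 nM on present data.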

Compound 4, half-maximal inhibitory concentration: 600 nM
For compound 4 the middle estimate is 2.2-fold (0.34 log units) above the measured one; the measured number falls inside the stated range.
By their numbers in this assay, from the lowest: compounds 4 and 3 (each within the scatter of the next); then compound 2. At a limit, above all of these: compound 1.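

Going by these compounds alone, the move from 4-fluorobenzyl to 2-chlorobenzyl, a 1.9-fold lower number from compound 3 to compound 4 (0.27 log units; within the scatter) in this assay, is the first exchange of one substituted phenyl for another at this place, and it leaves the two numbers within the scatter of each other. Putting 2-chlorophenyl in place of vinyl gives a 12-fold lower number from compound 2 to compound 4 (1.07 log units; beyond the scatter) and is a large step, so the gain over vinyl already seen with 4-fluorophenyl persists with this second substituted phenyl. The data shown give no cause for either step.

Open, going by these compounds, is how a longer chain, or a benzyl group carrying an amine or a carboxylic acid, would read at this place. Also open, on these data alone, is whether any other phenyl substitution there would move the number beyond the scatter.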